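Bromo in place of 4-fluorophenoxy

The source may report more compounds than this note shows. Statements on the series, on what has been measured and on what is new or still open speak of the compounds shown alone.

In a physicochemical assay for solubility, using the shake flask method, in simulated intestinal fluid, measured as kinetic solubility, with a stated time of 2 h, at 25 degrees C, at pH 6.5 (a lower number here means a less soluble compound, a higher number a more soluble compound), compound 1 (`Cc1nc(C(=O)OC2CC2)c(N)c2c1C(=O)N(Cc1ccccc1)C2=O`) gives 202000 nM and compound 2 (`Cc1nc(C(=O)N(C)C)c(N)c2c1C(=O)N(Cc1ccccc1)C2=O`) gives 172000 nM. Compound 3 (`Cc1noc(-c2nc(C)c3c(c2N)C(=O)N(Cc2ccc(Oc4ccc(F)cc4)cc2)C3=O)n1`) stands lowest of the three at 23800 nM, beyond the scatter from both. Compound 4 (`Cc1noc(-c2nc(C)c3c(c2N)C(=O)N(Cc2ccc(Br)cc2)C3=O)n1`) differs from it as follows: bromo in place of 4-fluorophenoxy on an aromatic carbon. For the measured compounds named here, the only measured step, a 1.2-fold lower number from compound 1 to compound 2 (0.07 log units; within the scatter), lies within the scatter and concerns another place, so it does not speak directly to this change. Going by the values given here, the sole guide is compound 1, at 202000 nM, and compound 2, at 172000 nM, which lack the 4-fluorophenoxy group but also differ elsewhere. A moderate rise is therefore expected, a 2.7-fold higher number from compound 3 to compound 4 (0.44 log units; beyond the scatter). For compound 4 the estimated value is 65000 nM, with an expected range of 25000 nM to 160000 nM.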

Compound 4, solubility: < 5000 nM
Compound 4: no number, only a limit (the forecaster's own chance of this, stated with the estimate: 5%); middle value at least 13-fold (1.11 log units) from the limit.
By their numbers in this assay, from the lowest: compound 3; then compounds 2 and 1 (each within the scatter of the next). At a limit, below all of these: compound 4.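

In this assay compound 4 gives < 5000 nM, a limit of the assay and not a number: the limit of < 5000 nM in this assay, at which 1 of the 4 values shown sits. For the compounds shown here, this is the first change read on this aromatic carbon, para to a large group, and bromo in place of 4-fluorophenoxy gives an at least 4.7-fold lower number from compound 3 to compound 4 (0.67 log units; beyond the scatter). Going by these compounds alone, at this place, then, losing the six-membered aromatic ring did not bring a higher number, and the earlier compounds could not show this. Going by these compounds, how far compound 4 lies under its limit stays open. Also open, on these data alone, is how an amine or a carboxylic acid on this carbon would read against compound 3.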